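Compound 3 against the limit of compound 2

The source may hold more compounds than are shown below. What is called first, only, known or untested is meant among the compounds shown, and "the series" means these compounds.

Measured in a functional assay on A549 cells (Homo sapiens) for antiproliferative activity, read by MTT assay, with a stated time of 72 h; a higher number here means a weaker inhibitor, a lower number a stronger inhibitor:
- compound 1 `O=C(Nc1ccc(Cl)c(-c2nnc3c(Cl)cccn23)c1)c1ccc(Cl)cc1`: 73600 nM
- compound 2 `CS(=O)(=O)c1ccc(C(=O)Nc2ccc(Cl)c(-c3nnc4c(Cl)cccn34)c2)cc1`: > 100000 nM (a limit)

Compound 2 gives > 100000 nM, which is a limit and not a number. (the limit of > 100000 nM in this assay, at which 1 of the 2 values shown sits).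

Compound 3 `O=C(Nc1ccc(Cl)c(-c2nnc3c(Cl)cccn23)c1)c1c(F)cccc1Cl` carries 2-chloro-6-fluorophenyl in place of 4-(methylsulfonyl)phenyl on a carbonyl carbon.

Among the compounds with values here, the one measured step bearing on this is an at least 1.3-fold higher number from compound 1 to compound 2 (0.13 log units; that floor lies within the scatter). Compound 3 also lacks the methylsulfonyl, so only a small move towards a lower number in this assay is expected, ending near compound 1 at 73600 nM.

The expected change is an at least 1.4-fold lower number from compound 2 to compound 3 (0.15 log units; that floor lies within the scatter).

Compound 3 is estimated at 70000 nM, with an expected range of 25000 nM to 100000 nM.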

Compound 3, half-maximal inhibitory concentration: 72300 nM
The estimate for compound 3 lay 1.0-fold (0.01 log units) below the measured number, within the range that was stated.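

In this assay, 2-chloro-6-fluorophenyl in place of 4-chlorophenyl on the carbonyl carbon gives a 1.0-fold lower number from compound 1 to compound 3 (0.01 log units; within the scatter), so these two halogen-bearing phenyl groups cannot be told apart at this place. Compound 2 stands only as a limit: the limit of > 100000 nM in this assay, at which 1 of the 3 values shown sits. The change from 4-(methylsulfonyl)phenyl gives an at least 1.3-fold lower number from compound 2 to compound 3 (0.14 log units; that floor lies within the scatter), so no order can be set between these two groups.

On these data alone, whether any change at this place moves the number beyond the scatter remains open. An amine, a carboxylic acid or a saturated cyclohexyl group here remains untested in the compounds shown.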